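A few compounds are considered here, and "the series" means these few. Any claim that something is new, unique, unknown or untested is made for them only; others in the source may bear on it.

Measured so far:
compound 1, `CC1=CSC2=NC(/C=C/c3cccc(Cl)c3)=C(C(=O)/C=C/c3cccc(Cl)c3)C(c3ccccc3)N12`, gives 286 ug/mL
compound 2, `CC1=CSC2=NC(/C=C/c3ccc(F)cc3)=C(C(=O)/C=C/c3ccc(F)cc3)C(c3ccccc3)N12`, gives 306 ug/mL
compound 3, `COc1ccc(C2C(C(=O)/C=C/c3cccs3)=C(/C=C/c3cccs3)N=C3SC=C(C)N32)cc1`, gives 235 ug/mL

All three were tested in an ADME assay on Vero cells (Chlorocebus sabaeus) for cytotoxicity, read by fluorescence and resazurin assay, with a stated time of 72 h; on this read-out higher numbers stand for lower toxicity in this test and lower numbers for higher toxicity in this test. On these numbers compound 1 stands second highest of the three; compound 2 is its nearest neighbour and compound 3 its furthest, yet both lie within the usual scatter of compound 1. The three measured compounds therefore cannot be told apart on this read-out.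

Compound 4, `CC1=CSC2=NC(/C=C/c3cccc(Cl)c3)=C(C(=O)/C=C/c3cccc(Cl)c3)C(c3ccc(Cl)cc3)N12`, has not been measured yet. It differs from compound 1 in one place: chloro in place of hydrogen on an aromatic carbon. Among the compounds with values here, no pair of measured compounds isolates this change, so there is no direct precedent for it. Compound 1 gives 286 ug/mL, compound 2 gives 306 ug/mL and compound 3 gives 235 ug/mL, and since these three, which differ from one another in larger ways, all land close together, a single added chloro is not expected to move the number far. The step of a 1.1-fold lower number from compound 1 to compound 4 (0.06 log units; within the scatter) is expected to be small, within the scatter or slightly toward a lower number. Compound 4 is therefore estimated at 250 ug/mL, with a range from 130 ug/mL to 450 ug/mL.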

Compound 4, half-maximal cytotoxic concentration: 317 ug/mL
Estimate against measurement, compound 4: 1.3-fold (0.10 log units) below; the measured number falls inside the stated range.
By their numbers in this assay, from the lowest: compounds 3, 1, 2 and 4 (each within the scatter of the next).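

In this assay, within the data shown here, the step from phenyl to 4-chlorophenyl gives a 1.1-fold higher number from compound 1 to compound 4 (0.04 log units; within the scatter) and is the first reading of a single change at this position, where the earlier compounds differed from one another in larger ways. A chloro on this aromatic carbon, para to a large group, therefore leaves the number indistinguishable from that of compound 1, so this one added atom has no effect that can be read in this test. No measurement here offers an explanation for this result.

This single pair cannot show whether the position would stay as unresponsive to a different kind of group, such as an amine or a carboxylic acid. It also leaves open whether the same chloro would behave alike on a different compound of this series.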